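The source may hold more compounds than are shown below. What is called first, only, known or untested is meant among the compounds shown, and "the series" means these compounds.

Compound 1 `C=CS(=O)(=O)c1cc(C(F)(F)F)cc(C(F)(F)F)c1`: in an ADME assay for pharmacokinetics, read by HPLC, in phosphate buffer, with a stated time of 72 h, at pH 7.4, tested at 250 uM (a lower number here means that the compound disappears faster, a higher number that the compound lasts longer), compound 1 reaches only a limit, < 0.017 h.
Compound 2 `C#Cc1cc(C(F)(F)F)cc(C(F)(F)F)c1`: in this assay compound 2 likewise reaches only a limit, > 50 h.

Compound 2 therefore stands at the long-lived end of what is shown; both values are limits, as the limit of < 0.017 h in this assay, at which 1 of the 2 values shown sits, and the limit of > 50 h in this assay, at which 1 of the 2 values shown sits, record. Among the compounds with values here, the single measured step, an at least 2900-fold higher number from compound 1 to compound 2 (3.46 log units; beyond the scatter), is large. Compound 3 `O=C(CBr)c1cc(C(F)(F)F)cc(C(F)(F)F)c1` differs from compound 2 by (bromomethyl)carbonyl in place of ethynyl on an aromatic carbon. No measured step covers this exchange; the one step shown only tells that changing this position can move the half-life strongly. A moderate decrease is expected, an at least 10-fold lower number from compound 2 to compound 3 (1.00 log units; beyond the scatter). Compound 3 is estimated at 5 h, within 0.5 h to 50 h.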

Compound 3, half-life: < 0.017 h
Compound 3: a limit, no number (the forecaster's own chance of this, stated with the estimate: 25%); middle value at least 290-fold (2.46 log units) away from the limit.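

In this assay, putting (bromomethyl)carbonyl in place of ethynyl gives an at least 2900-fold lower number from compound 2 to compound 3 (3.46 log units; beyond the scatter). Vinylsulfonyl is thus no longer the only group at this position found at the short-lived end of the scale: the limit of < 0.017 h in this assay, at which 2 of the 3 values shown sit. Between compound 1 and compound 3 no step can be read, as both values are limits.

Still open, going by these compounds, is whether a plain acetyl group, the same carbonyl without the bromine, would last as long as ethynyl. Also open, on these data alone, is where an amine or a carboxylic acid at this position would fall.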